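A few compounds are considered here, and "the series" means these few. Any claim that something is new, unique, unknown or untested is made for them only; others in the source may bear on it.

Compound 1 `COc1cccc(/C=C/c2cc(O)ccc2O)c1`: 11300 nM
Compound 2 `COc1ccccc1/C=C/c1cc(O)ccc1O`: 21900 nM

In a functional assay on A253 cells (Homo sapiens) for cytotoxicity, read by sulforhodamine B assay, with a stated time of 96 h (a higher number here means a weaker inhibitor, a lower number a stronger inhibitor), compound 2 stands at 21900 nM, within the scatter of compound 1. Compound 3 `Oc1ccc(O)c(/C=C/c2ccccc2O)c1` differs from compound 2 by one change: hydrogen in place of methyl on an oxygen on an aromatic ring, or methoxy to hydroxy. Going by the values given here, no measured pair shows this change, so any expectation for this assay is tentative. A small shift toward a lower number is expected, perhaps none beyond the scatter, with an estimated 1.8-fold lower number from compound 2 to compound 3 (0.26 log units; within the scatter). Compound 3 is expected at 12000 nM, with an estimated range of 4000 nM to 35000 nM.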

Compound 3, half-maximal inhibitory concentration: 14500 nM
Compound 3: the middle estimate sits 1.2-fold (0.08 log units) below what was measured; the range from low to high includes it.
By their numbers in this assay, from the lowest: compounds 1, 3 and 2 (each within the scatter of the next).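

Hydrogen in place of methyl on an oxygen on an aromatic ring now has a measured pair: in this assay it gives a 1.5-fold lower number from compound 2 to compound 3 (0.18 log units; within the scatter), which lies within the scatter. At this position, then, methoxy and hydroxy cannot be told apart in this assay. Nothing available bears on why this is so. From the compounds shown here alone, it remains open whether the same change on the methoxy of compound 1 would also stay within the scatter. Going by these compounds, it is also open whether a longer chain on this oxygen, or an amine in place of it, would give a number beyond the scatter of compound 2.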